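The source may hold more compounds than are shown below. What is called first, only, known or untested is meant among the compounds shown, and "the series" means these compounds.

Measured in a functional assay on MDA-MB-435 cells (Homo sapiens) for cytotoxicity, read by MTT assay, with a stated time of 72 h; a lower number here means a stronger inhibitor, a higher number a weaker inhibitor:
compound 1 `Nc1cccc(Nc2c(C(=O)NCc3ccc(F)cc3)nc(Br)c3cccnc23)c1` gives 8000 nM
compound 2 `O=C(NCc1ccc(F)cc1)c1nc(Br)c2cccnc2c1NCc1ccc(F)cc1` gives > 20000 nM (a limit of the assay, not a number)
compound 3 `N[C@H]1CC[C@H](Nc2c(C(=O)NCc3ccc(F)cc3)nc(Br)c3cccnc23)CC1` gives 6000 nM

Compound 3 sits level with compound 1 on these numbers, with a 1.3-fold lower number from compound 1 to compound 3 (0.12 log units; within the scatter) on the exchange of 3-aminophenyl for 4-aminocyclohexyl. Among the compounds with values here, compound 4 `NCCNc1c(C(=O)NCc2ccc(F)cc2)nc(Br)c2cccnc12` keeps the core of compound 3 and carries 2-aminoethyl in place of 4-aminocyclohexyl on a nitrogen on an aromatic ring as its only change.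

Within the data shown here, the closest precedent is a 1.3-fold lower number from compound 1 to compound 3 (0.12 log units; within the scatter) where one amino-bearing group replaces another. The steps beyond the scatter all involve the 4-fluorobenzyl group of compound 2, namely an at least 2.5-fold higher number from compound 1 to compound 2 (0.39 log units; beyond the scatter) and an at least 3.3-fold lower number from compound 2 to compound 3 (0.52 log units; beyond the scatter) in this series. Among the measured compounds shown here, since 2-aminoethyl also bears an amino group, no step beyond the scatter is expected in this assay, although this rests on only three compounds and none has a ring-free group. The expected step is a 1.2-fold higher number from compound 3 to compound 4 (0.07 log units; within the scatter) and it remains an estimate. Compound 4 is estimated at 7000 nM with an expected range of 2500 nM to 20000 nM in this assay.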

Compound 4, half-maximal inhibitory concentration: 12000 nM
Estimate against measurement, compound 4: 1.7-fold (0.23 log units) below; the measured number falls inside the stated range.
By their numbers in this assay, from the lowest: compounds 3, 1 and 4 (each within the scatter of the next). At a limit, above all of these: compound 2.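

In this assay, going from 7 heavy atoms with a ring to 3 heavy atoms with no ring on this nitrogen leaves the number within the scatter: a 2.0-fold higher number from compound 3 to compound 4 (0.30 log units; within the scatter), and a 1.5-fold higher number from compound 1 to compound 4 (0.18 log units; within the scatter). Among the amino-bearing groups shown, a ring on this nitrogen is therefore not needed for a number in this range. Against the 4-fluorobenzyl compound, the gain cannot be sized, and its floor lies within the scatter: an at least 1.6-fold lower number from compound 2 to compound 4 (0.22 log units; that floor lies within the scatter).

The value of compound 2 is a limit of the assay and not a number: the limit of > 20000 nM in this assay, at which 1 of the 4 values shown sits. Going by these compounds, what a 2-hydroxyethyl group or a longer 3-aminopropyl chain on this nitrogen would give remains open, and so does whether the amine of compound 4 matters at all.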